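The source may report more compounds than this note shows. Statements on the series, on what has been measured and on what is new or still open speak of the compounds shown alone.

Measured compounds:
compound 1 `Cc1noc(C)c1-c1ccc2c(c1)C(c1ccccc1)NC(=O)N2C` — 33.5%
compound 2 `Cc1nc(-c2ccccc2)sc1CN1C(=O)N(C)c2ccc(-c3c(C)noc3C)cc2C1c1ccccc1` — 35.1%
compound 3 `Cc1nc(-c2ccc(F)cc2)sc1CN1C(=O)N(C)c2ccc(-c3c(C)noc3C)cc2C1c1ccccc1` — 33.4%

In a functional assay on MCF7 cells (Homo sapiens) for inhibition, read by MTT assay, with a stated time of 48 h, tested at 2 uM (a lower number here means less inhibition, a higher number more inhibition at the concentration tested (going by the name of the read-out)), compound 2 gives 35.1%, the highest of the three numbers, though compound 1 and compound 3 both sit within the scatter of it; no order among the three can be claimed. Compound 1 carries only hydrogen on the ring amide nitrogen, yet in this assay compound 1 gives 33.5%, so the substituent on that nitrogen has not shown any effect beyond the scatter in this set.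

Compound 4 `Cc1noc(C)c1-c1ccc2c(c1)C(c1ccccc1)N(Cc1nc(-c3ccc(F)cc3)cs1)C(=O)N2C` is to be measured in this assay. It differs from compound 2 in one place: 4-(4-fluorophenyl)-1,3-thiazol-2-yl in place of 4-methyl-2-phenyl-1,3-thiazol-5-yl on a saturated chain carbon bound to an amide-type nitrogen in a ring. For the measured compounds named here, the one measured step that touches on this change is a number 1.7 percentage points lower from compound 2 to compound 3 (within the scatter), where the fluorophenyl motif also enters; that step is within the scatter. With both that step and the comparison of compound 1 with compound 2 showing nothing beyond scatter, the step of a number 2.1 percentage points lower from compound 2 to compound 4 (within the scatter) is what is expected, and it is estimated to lie within the scatter. Compound 4 is therefore estimated at 33%, with a range of 22% to 44%.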

Compound 4, a percentage reported as inhibition, at one concentration (the size of the read-out at that concentration, not a potency): 27.4%
Compound 4: middle estimate off by 5.6 percentage points, on the high side, and the stated range covers the measured number.
By their numbers in this assay, from the lowest: compounds 4, 3, 1 and 2 (each within the scatter of the next).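

In this assay, 4-(4-fluorophenyl)-1,3-thiazol-2-yl in place of 4-methyl-2-phenyl-1,3-thiazol-5-yl on a saturated chain carbon bound to an amide-type nitrogen in a ring gives a number 7.7 percentage points lower from compound 2 to compound 4 (within the scatter) and so leaves the number within the scatter. The position therefore accepts not only a fluoro on the phenyl ring, as in compound 3, but also a different attachment of the thiazole and the loss of its methyl, with no change that can be claimed at this single concentration. Because these differences enter together, compound 4 cannot assign any share of the step to one of them. Still open, on these data alone, is whether a basic amine or a carboxylic acid on the phenyl ring, or a longer chain in place of the single carbon, would move the number beyond the scatter. The data shown offer no measurement that explains the numbers at this position.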